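From a Trifluoromethoxy Group to a Fluorophenyl Group

The compounds below may be only part of what the source reports. "The series", "measured", "known", "first", "only" and "open" are said of these compounds alone.

Among the measured compounds shown here, in a functional assay on BXPC-3 cells (Homo sapiens) for cytotoxicity, read by MTT assay, with a stated time of 72 h (a lower number here means a stronger inhibitor, a higher number a weaker inhibitor), compound 1 `O=C1C(Nc2ccc(OC(F)(F)F)cc2)=CC(=O)c2ncncc21` gives 900 nM, the lowest of the two numbers known so far; compound 2 `O=C1C(Nc2ccc(CO)cc2)=CC(=O)c2ncncc21` gives 5700 nM, and the step of a 6.3-fold higher number from compound 1 to compound 2 (0.80 log units; beyond the scatter) accompanied hydroxymethyl in place of trifluoromethoxy on an aromatic carbon. Compound 3 `O=C1C(Nc2ccc(-c3ccc(F)cc3)cc2)=CC(=O)c2ncncc21` differs from compound 1 by 4-fluorophenyl in place of trifluoromethoxy on an aromatic carbon. For the measured compounds named here, only that one measured step concerns the same aromatic carbon, and it replaced the group with hydroxymethyl rather than with a ring, so it bears weakly on this change. One therefore expects a step of a 1.7-fold higher number from compound 1 to compound 3 (0.22 log units; within the scatter) in this assay, close to the scatter. Compound 3 is estimated at 1500 nM, with a range from 300 nM to 8000 nM.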

Compound 3, half-maximal inhibitory concentration: 4400 nM
Compound 3: the middle estimate sits 2.9-fold (0.47 log units) below what was measured, within the range that was stated.
By their numbers in this assay, from the lowest: compound 1; then compounds 3 and 2 (each within the scatter of the next).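

In this assay, 4-fluorophenyl also loses ground against trifluoromethoxy, with a 4.9-fold higher number from compound 1 to compound 3 (0.69 log units; beyond the scatter), so both replacements shown at this aromatic carbon, one with a ring and one with hydroxymethyl, move the number the same way. The two replacements cannot be told apart, with a 1.3-fold lower number from compound 2 to compound 3 (0.11 log units; within the scatter), although only one of them carries a ring. Nothing available here explains why either falls short of trifluoromethoxy. Going by these compounds, whether a methoxy group or a single fluorine on this carbon would stay near compound 1 remains open, as does how an amine would compare with hydroxymethyl.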